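Swapping the aryl group on the thiocarbonyl-bound nitrogen

The source may report more compounds than this note shows. Statements on the series, on what has been measured and on what is new or still open speak of the compounds shown alone.

Measured compounds:
Compound 1 `NC(=O)c1c(NC(=O)c2ccccc2Cl)sc2c1CCN(C(=O)Nc1ccccc1Cl)C2`: 12500 nM
Compound 2 `NC(=O)c1c(NC(=O)c2ccccc2Cl)sc2c1CCN(C(=S)Nc1ccccc1C(F)(F)F)C2`: 10600 nM

Both compounds share the same core and were tested in a functional assay on HL-60 cells (Homo sapiens) for antiproliferative activity, with a stated time of 24 h; on this read-out higher numbers stand for weaker inhibition and lower numbers for stronger inhibition. Compound 1 gives 12500 nM, and compound 2 gives 10600 nM. Compound 2 stands at the low end of these two numbers, but the gap to compound 1 lies within the usual scatter of repeated measurements, so the two cannot be told apart on this read-out. Going by the values given here, no pair of compounds differing in a single place has been measured, so no step size can be taken from the data.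

Compound 3 `NC(=O)c1c(NC(=O)c2ccccc2Cl)sc2c1CCN(C(=S)Nc1c(Cl)cccc1Cl)C2` has not yet been measured. It differs from compound 2 in one place: 2,6-dichlorophenyl in place of 2-(trifluoromethyl)phenyl on an amide-type nitrogen. Since nothing measured shows how this exchange affects this assay, and both measured compounds sit at a similar level, the expected step is small, with no direction beyond the scatter. Compound 3 is therefore estimated at 9500 nM, within a range of 3000 nM to 30000 nM, which means an expected step of a 1.1-fold lower number from compound 2 to compound 3 (0.05 log units; within the scatter).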

Compound 3, half-maximal inhibitory concentration: 3950 nM
For compound 3 the middle estimate is 2.4-fold (0.38 log units) above the measured one; low and high end bracket the measured number.
By their numbers in this assay, from the lowest: compound 3; then compounds 2 and 1 (each within the scatter of the next).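

In this assay, the aryl group on the amide-type nitrogen next to the thiocarbonyl carbon turns out to matter: 2,6-dichlorophenyl in place of 2-(trifluoromethyl)phenyl gives a 2.7-fold lower number from compound 2 to compound 3 (0.43 log units; beyond the scatter), the first difference in this set that clears the scatter. There is also a 3.2-fold lower number from compound 1 to compound 3 (0.50 log units; beyond the scatter), which makes compound 3 the strongest inhibitor of the three here, but that step swaps the carbonyl for a thiocarbonyl and changes the aryl group at once, so neither change can be credited on its own. No information is available that explains why this exchange lowers the number.

Still open, from the compounds shown here alone, is whether both chlorine atoms are needed, a question that a plain phenyl group or a 2-chlorophenyl group on this same nitrogen would help to settle. Also open, going by these compounds, is whether an aromatic ring is needed here at all, which a cyclohexyl group or a short alkyl chain in its place would test.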